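The source may report more compounds than this note shows. Statements on the series, on what has been measured and on what is new or still open speak of the compounds shown alone.

Compound 1, `COc1ccc2c(=O)c(/C=C/C(=O)Nc3ccccc3)coc2c1`, is the reference point here. In an ADME assay on HepG2 2.2.15 cells (Homo sapiens) for cytotoxicity, read by MTT assay, with stated times of 48 h and 9 days (on this read-out higher numbers stand for lower toxicity in this test and lower numbers for higher toxicity in this test), compound 1 gives 523000 nM. Compound 2, `COc1ccc2c(=O)c(/C=C/C(=O)NCc3ccc(C)cc3)coc2c1`, carries a 4-methylbenzyl on the amide-type nitrogen where compound 1 carries a phenyl, and in this assay compound 2 gives 257000 nM. Among the compounds with values here, the single measured step, a 2.0-fold lower number from compound 1 to compound 2 (0.31 log units; beyond the scatter), is a modest one. On the numbers shown, compound 2 therefore stands as the lower of the two, with compound 1 its only neighbour.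

Compound 3, `COc1ccc2c(=O)c(/C=C/C(=O)Nc3ccc(C)cc3)coc2c1`, differs from compound 2 in one place: 4-methylphenyl in place of 4-methylbenzyl on an amide-type nitrogen. Within the data shown here, only the step from compound 1 to compound 2 bears on this change, and it sets compound 3 structurally between the two measured compounds, sharing the aryl attachment of compound 1 and the methyl of compound 2. The account thus expects compound 3 to move back toward compound 1 by a step of about a 1.6-fold higher number from compound 2 to compound 3 (0.19 log units; within the scatter), modest at most and possibly within the scatter. In this assay compound 3 is estimated at 400000 nM, with a range from 200000 nM to 800000 nM.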

Compound 3, half-maximal cytotoxic concentration: 979000 nM
Estimate against measurement, compound 3: 2.4-fold (0.39 log units) below; the whole stated range lies below it.
By their numbers in this assay, from the lowest: compound 2; then compounds 1 and 3 (each within the scatter of the next).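

In this assay, within the data shown here, the change from 4-methylbenzyl to 4-methylphenyl on the amide-type nitrogen gives a 3.8-fold higher number from compound 2 to compound 3 (0.58 log units; beyond the scatter), and this is the first step here in which the methyl stays while the group attached to the nitrogen changes from benzyl to phenyl. The methyl on an aromatic carbon, taken alone, gives a 1.9-fold higher number from compound 1 to compound 3 (0.27 log units; within the scatter), so compound 1 and compound 3 cannot be told apart in this test, and the lower number of compound 2 goes with the 4-methylbenzyl group rather than with the methyl. Nothing measured here offers a reason for this difference.

With compound 2 as the only benzyl compound shown, it remains open whether the lower number belongs to the benzyl group as such or depends on its methyl, a question that a plain unsubstituted benzyl on the same nitrogen would address. From the compounds shown here alone, it also remains open how a longer chain such as phenethyl on that nitrogen, or an amine or a carboxylic acid in place of the methyl, would read in this test.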